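Bromo-difluorophenyl variant: what the halogen series suggests

This account rests on a few compounds, and the source may have more. Where it says the series, first, only, none or still open, it means among the compounds named here.

Three compounds have been measured in an assay on isolated protein for inhibition of acyl-CoA desaturase 1 (Rattus norvegicus); on this read-out lower numbers stand for stronger inhibition and higher numbers for weaker inhibition:

Compound 1, `O=C(O)c1cccc(-c2ccc(N3CCC(Oc4ccccc4C(F)(F)F)CC3)nn2)c1`, gives 107 nM.
Compound 2, `O=C(O)c1cncc(-c2ccc(N3CCC(Oc4ccccc4Cl)CC3)nn2)c1`, gives 166 nM.
Compound 3, `O=C(O)c1cncc(-c2ccc(N3CCC(Oc4ccccc4I)CC3)nn2)c1`, gives 27 nM.

Compound 2 has the highest number of the three, though its gap to compound 1 lies within the scatter; only compound 3 stands clearly apart from it. Going by the values given here, the single step that connects measured compounds, a 6.1-fold lower number from compound 2 to compound 3 (0.79 log units; beyond the scatter), shows what swapping the halogen on the phenyl ether can do.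

Compound 4, `O=C(O)c1cncc(-c2ccc(N3CCC(Oc4cc(F)c(F)cc4Br)CC3)nn2)c1`, differs from compound 2 as follows: 2-bromo-4,5-difluorophenyl in place of 2-chlorophenyl on an oxygen on a saturated carbon. One part of this change, a heavier halogen in the same place, resembles the step to compound 3, which lowered the number beyond the scatter. Among the compounds with values here, the two fluorines have no counterpart among the measured compounds, so their effect is unknown. A lowering is therefore expected, but smaller and less certain than the step to compound 3; the expected step is a 2.8-fold lower number from compound 2 to compound 4 (0.44 log units; beyond the scatter). For compound 4 the estimate in this assay is 60 nM, with a range from 20 nM to 180 nM.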

Compound 4, half-maximal inhibitory concentration: 15 nM
For compound 4 the middle estimate is 4.0-fold (0.60 log units) above the measured one; measured number below the stated range.
By their numbers in this assay, from the lowest: compounds 4 and 3 (each within the scatter of the next); then compounds 1 and 2 (each within the scatter of the next).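

In this assay, replacing the single halogen on the phenyl ether with a more heavily substituted ring is compatible with a large gain: the full change gives an 11-fold lower number from compound 2 to compound 4 (1.04 log units; beyond the scatter) on the same shared core. Set against the iodo group, the new ring gives a 1.8-fold lower number from compound 3 to compound 4 (0.26 log units; within the scatter) and this lies within the scatter, so the two groups cannot be ranked, and more than one substitution pattern on this ring reaches the same range of numbers. No supporting data are available to explain why either group gives these lower numbers.

On these data alone, the bromine and the two fluorines entered together, so their separate shares remain unknown, and a plain 2-bromophenyl group or a 4,5-difluorophenyl group without bromine would be needed to divide them. As far as these compounds go, whether a nitrile or a methoxy group could take the place of the halogen on this ring also remains open.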